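This account rests on a few compounds, and the source may have more. Where it says the series, first, only, none or still open, it means among the compounds named here.

Measured compounds, largest response reached:

- compound 1, `Cc1nc(-c2ccccc2NCC2=NCCN2)n(C)n1`: 0%
- compound 2, `CCn1ccc(-c2ccccc2NCC2=NCCN2)n1`: 0%
- compound 3, `Cc1ccc(-c2ccccc2NCC2=NCCN2)n1C`: 0%

In a functional assay with Alpha-1B adrenergic receptor (Homo sapiens) as the target, read by calcium flux (on this read-out lower numbers stand for smaller maximal responses and higher numbers for larger maximal responses), compound 1 gives 0%. Compound 2 gives 0% and compound 3 gives 0% in this assay, so compound 1 stands level with both at the digits recorded, and none of the three is set apart from the others by more than the scatter. Within the data shown here, no pair among them differs in one place only, so no single-point step is available within the measured set; all that can be said is that three different five-membered aromatic rings on the shared core of compound 1 give the same flat read-out.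

The next compound is compound 4, `Cn1ncnc1-c1ccccc1NCC1=NCCN1`. It differs from compound 1 by hydrogen in place of methyl on an aromatic carbon; the site is on an aromatic carbon of a five-membered aromatic ring with 3 nitrogen, between two ring nitrogen atoms.

With every measured compound at the same flat value in this assay, no step beyond the scatter is expected in either direction for the removal of the methyl. The expected step of no change at the digits printed from compound 1 to compound 4 (within the scatter) is therefore none beyond the scatter. Compound 4 is accordingly estimated at 0%, with a range from -5% to 10%.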

Compound 4, largest response reached (reported as maximal response), in percent of the reference or control that the assay uses: 93%
Compound 4: the middle estimate sits 93 percentage points below what was measured, outside the stated range (above it).
By their numbers in this assay, from the lowest: compounds 1, 2 and 3 (each within the scatter of the next); then compound 4.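

In this assay, among these compounds, hydrogen in place of methyl on an aromatic carbon of the five-membered aromatic ring with 3 nitrogen gives a number 93 percentage points higher from compound 1 to compound 4 (beyond the scatter), the first single-place step. The earlier compounds shown here gave only a flat read-out across different rings, with no way to tell whether any one site mattered; this pair shows that the ring carbon between two ring nitrogen atoms is a site where the read-out responds strongly, and that a change of 1 heavy atom there is enough to separate a flat read-out from a large response. No measurement at hand bears on the reason for this step.

From the compounds shown here alone, only methyl and hydrogen are compared at this carbon, so it remains open whether the response falls away gradually or abruptly with other groups there, such as fluorine, an amine, a carboxylic acid or a longer chain. Going by these compounds, it also remains open whether removing a methyl group from the ring of compound 3 would give a similar step, or whether this one is particular to the ring shared by compound 1 and compound 4.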